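Chain-end pyridine on an octyl carbamate

The source may hold more compounds than are shown below. What is called first, only, known or untested is meant among the compounds shown, and "the series" means these compounds.

Compound 1 `CCCCCCCCOC(=O)N[C@H]1CNC1=O` is an octyl carbamate of the shared core. Among the measured compounds shown here, in an assay on HEK293 cells for inhibition of N-acylethanolamine-hydrolyzing acid amidase (Homo sapiens), read by fluorescence, with stated times of 10 min and 50 min (a higher number here means a weaker inhibitor, a lower number a stronger inhibitor), compound 1 gives 37 nM, the lower of the two numbers so far, with compound 2 `O=C(N[C@H]1CNC1=O)OCCCCCC1CCCCC1` close by at 49 nM. For the measured compounds named here, the only measured step, cyclohexyl in place of propyl at the chain end, ran a 1.3-fold higher number from compound 1 to compound 2 (0.12 log units; within the scatter), so exchanging a terminal alkyl piece for a saturated ring left the number essentially where it was. Compound 3 `O=C(N[C@H]1CNC1=O)OCCCCc1ccccn1` differs from compound 1 by pyridin-2-yl in place of butyl on a saturated chain carbon, four bonds along the chain from an oxygen next to a carbonyl group; the chain is thus shortened and ends in an aromatic ring carrying one hydrogen-bond acceptor. Going by the values given here, no measured step covers an aromatic or heteroaromatic end group, so the change is only partly comparable to that from compound 1 to compound 2. On that basis compound 3 is expected to give about 60 nM, within 20 nM to 200 nM, in this assay. The estimated step of a 1.6-fold higher number from compound 1 to compound 3 (0.21 log units; within the scatter) is expected to be small, with a slight lean toward a higher number.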

Compound 3, half-maximal inhibitory concentration: 30700 nM
Beside the measured number, compound 3's estimate is 510-fold (2.71 log units) below it; the measured number lies above the stated range.
By their numbers in this assay, from the lowest: compounds 1 and 2 (each within the scatter of the next); then compound 3.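

With pyridin-2-yl in place of butyl, this assay shows an 830-fold higher number from compound 1 to compound 3 (2.92 log units; beyond the scatter) while cyclohexyl in place of propyl showed only a 1.3-fold higher number from compound 1 to compound 2 (0.12 log units; within the scatter) on the same chain. The chain end of compound 1 therefore does not accept every exchange: a saturated ring five bonds along the chain left the number within the scatter, whereas a six-membered aromatic ring with one hetero atom four bonds along the chain gave a large rise. Nothing available gives a reason for this large rise.

Compound 3 changes both the end group and its place along the chain, so the two changes cannot be told apart here. A phenyl group at the same place, or pyridin-2-yl on a longer chain, would be needed to separate them.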